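Chain oxygens in a carbamate tail: compound 4 estimated

This account rests on a few compounds, and the source may have more. Where it says the series, first, only, none or still open, it means among the compounds named here.

Compound 1 `CCCCNC(=O)Oc1cccc(-n2ccc(C(N)=O)c2)c1`: 60 nM
Compound 2 `NC(=O)c1ccn(-c2cccc(OC(=O)NCCCCCCc3ccccc3)c2)c1`: 0.16 nM
Compound 3 `Cc1oc(-c2cccc(OC(=O)NCCCCCCc3ccccc3)c2)cc1C(N)=O`: 4.8 nM

In an assay (brain) for inhibition of Fatty-acid amide hydrolase 1 (Mus musculus), with stated times of 20 min and 15 min (a lower number here means a stronger inhibitor, a higher number a weaker inhibitor), compound 2 gives the lowest of the three numbers; the nearest is compound 3 a 30-fold higher number from compound 2 to compound 3 (1.48 log units; beyond the scatter), and the furthest is compound 1 a 380-fold lower number from compound 1 to compound 2 (2.57 log units; beyond the scatter). Compound 4 `NC(=O)c1ccn(-c2cccc(OC(=O)NCCOCCOc3ccccc3)c2)c1` has not been measured. It differs from compound 2 in one place: 2-phenoxyethoxy in place of 4-phenylbutyl on a saturated chain carbon, two bonds along the chain from an amide-type nitrogen.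

Going by the values given here, the step that bears on this change is the one from compound 1 to compound 2, which shows how strongly the extension of the chain by phenethyl lowered the number in this assay a 380-fold lower number from compound 1 to compound 2 (2.57 log units; beyond the scatter). Among the compounds with values here, compound 4 keeps a phenyl at the end of a chain of the same length, so most of that gain is expected to remain, but two chain carbons become oxygens, and no measured step shows the effect of that exchange. A moderate rise in the number is therefore expected for compound 4, a 13-fold higher number from compound 2 to compound 4 (1.10 log units; beyond the scatter). The estimate for compound 4 in this assay is 2 nM, with a range from 0.3 nM to 15 nM.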

Compound 4, inhibition constant: 23 nM
Beside the measured number, compound 4's estimate is 12-fold (1.06 log units) below it, and the stated range ends below it.
By their numbers in this assay, from the lowest: compound 2; then compound 3; then compound 4; then compound 1.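

Going by these compounds alone, the chain position tolerates far less than the earlier compounds suggested: in this assay, 2-phenoxyethoxy in place of 4-phenylbutyl, on a saturated chain carbon two bonds along the chain from an amide-type nitrogen, gives a 140-fold higher number from compound 2 to compound 4 (2.16 log units; beyond the scatter). The entering and leaving groups have the same count of heavy atoms and the same terminal aromatic ring, so a phenyl-ended chain of this size does not by itself secure the low number of compound 2. Most of the gain seen with the all-carbon tail is gone, leaving only a 2.6-fold lower number from compound 1 to compound 4 (0.42 log units; beyond the scatter), a modest step though beyond the scatter.

The compounds shown do not tell whether one chain oxygen alone would have the same effect, or how a chain amine at that place would compare. Nothing available here accounts for the size of this loss.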